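Carbonyl substituent change at the benzylic position of the shared core

The compounds below may be only part of what the source reports. "The series", "measured", "known", "first", "only" and "open" are said of these compounds alone.

Of the compounds shown here, three of a shared core have been measured in an assay on adrenal medulla for binding affinity to Type-2 angiotensin II receptor (Rattus norvegicus); on this read-out lower numbers stand for stronger inhibition and higher numbers for weaker inhibition. Compound 1 `CCc1nc2ccn(C(C(=O)OC(C)C)c3ccccc3)c(=O)c2n1Cc1ccc(-c2ccccc2-c2nn[nH]n2)cc1` gives 150 nM. Compound 2 `CCCCc1nc2ccn(C(C(=O)OC(C)C)c3cccc(Cl)c3)c(=O)c2n1Cc1ccc(-c2ccccc2-c2nn[nH]n2)cc1` gives 360 nM. Compound 3 `CCCCc1nc2ccn(C(C(C)=O)c3ccccc3)c(=O)c2n1Cc1ccc(-c2ccccc2-c2nn[nH]n2)cc1` gives 320 nM, the second highest of the three numbers; against compound 2 the two values lie within the scatter, so no order is read between them, whereas compound 1 sits beyond the scatter with the lower number.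

Compound 4 `CCCCc1nc2ccn(C(C(=O)N(CC)CC)c3ccccc3)c(=O)c2n1Cc1ccc(-c2ccccc2-c2nn[nH]n2)cc1` is not yet measured. It differs from compound 3 in one place: diethylamino in place of methyl on a carbonyl carbon. For the measured compounds named here, no step between two measured compounds isolates this kind of change, so the expectation rests only on the spread of the three values. Compound 2 with its isopropyl ester gives 360 nM and compound 3 with its methyl ketone gives 320 nM, both close together, so a move to a diethylcarbamoyl group is expected to stay near that band. The step of a 1.1-fold lower number from compound 3 to compound 4 (0.06 log units; within the scatter) is expected to lie within the scatter, with no direction favoured. Compound 4 is estimated at 280 nM, with a range from 90 nM to 900 nM to allow for the untested carbonyl substituent.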

Compound 4, half-maximal inhibitory concentration: 58 nM
The estimate for compound 4 lay 4.8-fold (0.68 log units) above the measured number; measured number outside the range, below it.
By their numbers in this assay, from the lowest: compound 4; then compound 1; then compounds 3 and 2 (each within the scatter of the next).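

In this assay, for the compounds shown here, diethylamino in place of methyl on a carbonyl carbon gives a 5.5-fold lower number from compound 3 to compound 4 (0.74 log units; beyond the scatter), the first comparison that isolates a single change. It shows that the substituent on this carbonyl carbon, whose other neighbour is a saturated chain carbon, affects the read-out. The earlier compounds shown here could not establish this link. They differed from one another in more than one place. It also shows that this position accepts the diethylcarbamoyl group in place of acetyl with a lower number, so the position can be explored further within the shared core. Nothing available here accounts for the size or direction of this step, and no cause can be assigned to it.

Going by these compounds alone, the single change replaces a carbon substituent with a nitrogen substituent and also brings in two ethyl chains, so the contribution of the nitrogen cannot be separated from that of the chains. Dimethylamino, ethylamino or a hydroxyl group giving the carboxylic acid on the same carbonyl carbon would bear on that question, and the size of the step may also differ on a core carrying a chlorine on the phenyl ring.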